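The compounds below may be only part of what the source reports. "The series", "measured", "known", "first", "only" and "open" are said of these compounds alone.

Measured so far:
Compound 1 `O=C(/C=C/c1cccnc1)NCCCCc1ccc(S(=O)(=O)Nc2ccccc2)cc1`: 47.9 nM
Compound 2 `Cc1ccccc1NS(=O)(=O)c1cccc(CCCCCCNC(=O)/C=C/c2cccnc2)c1`: 2.9 nM

Both numbers come from a functional assay on DU-145 cells (Homo sapiens) for inhibition, read by CCK-8 assay, with a stated time of 72 h; a lower number here means a stronger inhibitor, a higher number a weaker inhibitor. Compound 2, at 2.9 nM, holds the lower of the two numbers, and the gap to compound 1 lies beyond the usual scatter of repeated measurements. Compound 2 is therefore the stronger inhibitor of this pair, and it makes the natural starting point for the next comparison.

That comparison is with compound 3 `O=C(/C=C/c1cccnc1)NCCCCCCc1cccc(S(=O)(=O)Nc2ccc(F)c(Cl)c2)c1`, which has not yet been measured. It carries 3-chloro-4-fluorophenyl in place of 2-methylphenyl on a sulfonamide nitrogen. The rest of the structure stays the same.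

Among the measured compounds shown here, no two measured compounds differ in only one place, so the data offer no direct guide to the size of this swap. Any expectation here is therefore tentative. One six-membered aromatic ring replaces another, and only a modest shift toward weaker inhibition is expected. The expected change is an estimated 1.4-fold higher number from compound 2 to compound 3 (0.14 log units; within the scatter), which would not lie beyond the scatter. For compound 3, the estimated value is 4 nM, with an expected range of 1 nM to 16 nM.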

Compound 3, half-maximal inhibitory concentration: 150 nM
Estimate against measurement, compound 3: 38-fold (1.57 log units) below; the measured number lies above the stated range.
By their numbers in this assay, from the lowest: compound 2; then compound 1; then compound 3.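

In this assay, among the compounds shown here, this is the first comparison in which only one place changes, and it shows that the group on the sulfonamide nitrogen matters a great deal: 3-chloro-4-fluorophenyl in place of 2-methylphenyl gives a 52-fold higher number from compound 2 to compound 3 (1.71 log units; beyond the scatter). On paper the two groups look much alike, each being one six-membered aromatic ring of carbon only with no hydrogen-bond donors or acceptors, so such simple counts do not predict how well a compound inhibits at this position. No supporting measurement bears on why the number rises so far, and the cause remains unknown.

The swap removes the methyl group and adds the chlorine and the fluorine in a single step, so the compounds shown cannot say which of these changes carries the loss. Also open, as far as these compounds go, is how this nitrogen would respond to a 3-chlorophenyl group, a 4-fluorophenyl group, or a non-aromatic ring such as cyclohexyl, any of which would help separate these contributions.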